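Varying the Terminal Amine in Vasopressin V2 Receptor Ligands

This account rests on a few compounds, and the source may have more. Where it says the series, first, only, none or still open, it means among the compounds named here.

Compound 1, `CN(C)C1CCN(C(=O)CCCOc2cc(C(=O)N3CCCCc4sccc43)ccc2NC(=O)c2ccccc2-c2ccccc2)CC1`: 20 nM
Compound 2, `CN1CCN(C(=O)CCCOc2cc(C(=O)N3CCCCc4sccc43)ccc2NC(=O)c2ccccc2-c2ccccc2)CC1`: 6 nM
Compound 3, `O=C(Nc1ccc(C(=O)N2CCCCc3sccc32)cc1OCCCC(=O)N1CCC(N2CCCCC2)CC1)c1ccccc1-c1ccccc1`: 30 nM

In an assay on CHO cells for inhibition of Vasopressin V2 receptor (Homo sapiens), read by radioligand binding (on this read-out higher numbers stand for weaker inhibition and lower numbers for stronger inhibition), compound 3 gives 30 nM, the highest of the three numbers. Its gap to compound 1 is within the scatter (a 1.5-fold higher number from compound 1 to compound 3 (0.18 log units; within the scatter)), whereas compound 2 stands clearly apart (a 5.0-fold higher number from compound 2 to compound 3 (0.70 log units; beyond the scatter)). Compound 4, `CCN(CC)C1CCN(C(=O)CCCOc2cc(C(=O)N3CCCCc4sccc43)ccc2NC(=O)c2ccccc2-c2ccccc2)CC1`, differs from compound 3 by diethylamino in place of piperidin-1-yl on a saturated ring carbon. Going by the values given here, the one measured step that bears on this change is the exchange of dimethylamino for piperidin-1-yl at the same position, a 1.5-fold higher number from compound 1 to compound 3 (0.18 log units; within the scatter), which stayed within the scatter. Diethylamino is expected to behave like those two amines, so the step from compound 3 is expected to be a 1.2-fold lower number from compound 3 to compound 4 (0.08 log units; within the scatter), none beyond the scatter. Compound 4 is therefore estimated at 25 nM, with a range from 10 nM to 60 nM.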

Compound 4, half-maximal inhibitory concentration: 9 nM
The estimate for compound 4 lay 2.8-fold (0.44 log units) above the measured number; measured number below the stated range.
By their numbers in this assay, from the lowest: compounds 2 and 4 (each within the scatter of the next); then compounds 1 and 3 (each within the scatter of the next).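

Dimethylamino and piperidin-1-yl on this saturated ring carbon had stayed within the scatter of each other, so the amine here looked like a place where little changed. Diethylamino breaks that picture, standing apart from piperidin-1-yl (a 3.3-fold lower number from compound 3 to compound 4 (0.52 log units; beyond the scatter)) and from dimethylamino (a 2.2-fold lower number from compound 1 to compound 4 (0.35 log units; beyond the scatter)). The 4-(diethylamino)piperidin-1-yl group also shows no separation from 4-methylpiperazin-1-yl (a 1.5-fold higher number from compound 2 to compound 4 (0.18 log units; within the scatter)).

The compounds shown leave open how pyrrolidin-1-yl or dipropylamino on this carbon would compare with diethylamino. No evidence at hand explains the step from piperidin-1-yl to diethylamino.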